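From 3-chlorophenyl to 2,3-dichlorophenyl: a second chloro

The source may report more compounds than this note shows. Statements on the series, on what has been measured and on what is new or still open speak of the compounds shown alone.

Of the compounds shown here, three sharing one core have been tested in a functional assay on the whole organism (strain Kunming) for inhibition, with Mus musculus as the target, with a stated time of 1 h, at a dose of 40 mg/kg by the oral route; a lower number here means less inhibition, a higher number more inhibition at the dose given (going by the name of the read-out). Compound 1 `O=C(/C=C/c1ccccc1)c1ccc(N2CCN(c3ccc(Cl)c(Cl)c3)CC2)cc1` gives 13.4%. Compound 2 `Cc1ccc(N2CCN(c3ccc(C(=O)/C=C/c4ccccc4)cc3)CC2)c(C)c1` gives 15% in this assay. Compound 3 `O=C(/C=C/c1ccccc1)c1ccc(N2CCN(c3cccc(Cl)c3)CC2)cc1` gives 14.1% in this assay. The three numbers lie close together: a number 0.7 percentage points higher from compound 1 to compound 3 (within the scatter), a number 1.6 percentage points higher from compound 1 to compound 2 (within the scatter) and a number 0.9 percentage points lower from compound 2 to compound 3 (within the scatter), so compound 3 stands with compound 1 nearest and compound 2 furthest, every gap within the scatter.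

Compound 4 `O=C(/C=C/c1ccccc1)c1ccc(N2CCN(c3cccc(Cl)c3Cl)CC2)cc1` differs from compound 3 in one place: chloro in place of hydrogen on an aromatic carbon. The measured step most closely related to this change runs the other way, a chloro leaving an aromatic carbon, and read a number 0.7 percentage points higher from compound 1 to compound 3 (within the scatter). The two steps that exchange the whole group on the amine nitrogen in a ring, a number 1.6 percentage points higher from compound 1 to compound 2 (within the scatter) and a number 0.9 percentage points lower from compound 2 to compound 3 (within the scatter), were likewise within the scatter. Among the compounds with values here, nothing among the measured compounds shows that adding or removing a chloro on this ring moves the read-out beyond the scatter, so no step beyond the scatter is expected in either direction. Compound 4 is therefore expected to give 14% in this assay, with a range of 5% to 24%. That expectation means a step of a number 0.1 percentage points lower from compound 3 to compound 4 (within the scatter).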

Compound 4, a percentage reported as inhibition, in the whole organism at one dose (the size of the read-out at that dose, not a potency): 30.7%
Compound 4: middle estimate off by 16.7 percentage points, on the low side; the whole stated range lies below it.
By their numbers in this assay, from the lowest: compounds 1, 3 and 2 (each within the scatter of the next); then compound 4.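

In this assay, within the data shown here, a second chloro on an aromatic carbon, ortho to a chloro group and ortho to a large group, gives the first step beyond the scatter: a number 16.6 percentage points higher from compound 3 to compound 4 (beyond the scatter). The 2,3-dichlorophenyl group also stands apart from the other two groups on the amine nitrogen, with a number 17.3 percentage points higher from compound 1 to compound 4 (beyond the scatter) and a number 15.7 percentage points higher from compound 2 to compound 4 (beyond the scatter); the count of chloro groups alone does not settle the read-out, since the 3,4-dichlorophenyl group of compound 1 also carries two and its value lies within the scatter of compound 3. The compounds shown come with no measurement that explains why this arrangement of chloro groups goes with the higher read-out.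

Going by these compounds, whether another group in the same place, such as bromo, fluoro, methyl or methoxy, would give a step of similar size remains open. The read-out also comes from a single dose and a single time, so the compounds shown leave open whether the difference of compound 4 from the others would hold at other doses.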